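Ring-nitrogen substituent: from compound 2 to compound 3

The compounds below may be only part of what the source reports. "The series", "measured", "known", "first", "only" and "open" are said of these compounds alone.

Of the compounds shown here, two of the shared core have so far been measured in a functional assay on the whole organism (strain CF-1 albino) with Mus musculus as the target, with a stated time of 4 h; a higher number here means that more compound is needed for the effect, a lower number that less compound is needed. Compound 1 `O=C1CC(c2ccccc2Br)C(=O)N1CN1CCN(c2ccccc2)CC1` gives 100 mg/kg. Compound 2 `O=C1CC(c2ccccc2Br)C(=O)N1CN1CCN(c2ccc(Cl)cc2)CC1` gives 300 mg/kg, the highest of the two numbers in hand, reached by a 3.0-fold higher number from compound 1 to compound 2 (0.48 log units; beyond the scatter). Compound 3 `O=C1CC(c2ccccc2Br)C(=O)N1CN1CCN(C2CCCCC2)CC1` carries cyclohexyl in place of 4-chlorophenyl on an amine nitrogen in a ring. Among the compounds with values here, no measured step bears directly on this change; the only step available concerns chloro in place of hydrogen on an aromatic carbon, and it was modest. The change leading to compound 3 removes the chloro group together with its aromatic ring, so the direction of any step is open. A modest step toward a lower number is expected, a 1.5-fold lower number from compound 2 to compound 3 (0.18 log units; within the scatter), resting on compound 1 at 100 mg/kg as the nearest point without chlorine. Compound 3 is estimated at 200 mg/kg, within a range from 70 mg/kg to 600 mg/kg.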

Compound 3, minimum effective dose: 100 mg/kg
Compound 3: middle estimate off by 2.0-fold (0.30 log units), on the high side; measured number inside the range.
By their numbers in this assay, from the lowest: compounds 1 and 3 (each within the scatter of the next); then compound 2.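

In this assay cyclohexyl in place of 4-chlorophenyl on the amine nitrogen in a ring gives a 3.0-fold lower number from compound 2 to compound 3 (0.48 log units; beyond the scatter) and cyclohexyl in place of phenyl gives no change at the digits printed from compound 1 to compound 3 (within the scatter) so at this position the number of compound 1 is kept without an aromatic ring. Of the three groups compared here, only 4-chlorophenyl stands apart, while phenyl and cyclohexyl cannot be told apart in this assay. No supporting data are available to explain this pattern.

The compounds shown leave open whether the higher number is specific to chloro or also appears with fluoro or methoxy on the phenyl ring. They also leave open how a group without a ring, such as methyl or a longer chain, would read on this nitrogen.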